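The source may hold more compounds than are shown below. What is called first, only, known or untested is meant among the compounds shown, and "the series" means these compounds.

In a functional assay on the whole organism with Mus musculus as the target (a higher number here means that more compound is needed for the effect, a lower number that less compound is needed), compound 1 (`Cc1cc(CCC(=O)O)ccc1-c1noc(-c2ccc(OC(C)C)c(C#N)c2)n1`) gives 0.1 mg/kg and compound 2 (`Cc1cc([C@@H]2C[C@H]2C(=O)O)ccc1-c1noc(-c2ccc(OC(C)C)c(C(F)(F)F)c2)n1`) gives 0.2 mg/kg. These two numbers lie within the usual scatter of each other, so compound 2 cannot yet be told apart from compound 1. Compound 3 (`Cc1cc(C(C)CC(=O)O)ccc1-c1noc(-c2ccc(OC(C)C)c(C(F)(F)F)c2)n1`) differs from compound 2 in one group: 1-(carboxymethyl)ethyl in place of 2-carboxycyclopropyl on an aromatic carbon. In words, 1-(carboxymethyl)ethyl stands in place of 2-carboxycyclopropyl on an aromatic carbon, and the three-membered ring is gone. Among the compounds with values here, no measured pair of compounds shows this change on its own, so any forecast is a judgement. Compound 1, which also has no three-membered ring at this place, gives 0.1 mg/kg, so no step beyond the scatter is expected in this assay. The expected step is a 1.5-fold higher number from compound 2 to compound 3 (0.18 log units; within the scatter). For compound 3 the estimated value is 0.3 mg/kg, with an expected range from 0.1 mg/kg to 1 mg/kg.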

Compound 3, dose for half-maximal effect: 0.1 mg/kg
Compound 3: middle estimate off by 3.0-fold (0.48 log units), on the high side; low and high end bracket the measured number.
By their numbers in this assay, from the lowest: compounds 1, 3 and 2 (each within the scatter of the next).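

In this assay the open 1-(carboxymethyl)ethyl, put in place of 2-carboxycyclopropyl, gives a 2.0-fold lower number from compound 2 to compound 3 (0.30 log units; within the scatter) and so cannot be told apart from the ring-bearing compound. At this place, on an aromatic carbon para to a large group, the three-membered ring and its two defined stereocentres can therefore go without a detectable shift in the dose needed. The heavy-atom count stays the same across this swap, and nothing measured here accounts for the two groups giving such similar numbers.

All the compounds shown keep a carboxylic acid on this side chain, so what an amine or a primary amide would do here stays open. Also open, from the compounds shown here alone, is how a longer chain between the aromatic ring and the acid would read in this assay.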